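The source may hold more compounds than are shown below. What is called first, only, known or untested is meant among the compounds shown, and "the series" means these compounds.

In an assay on HeLa cells for displacement of a labelled ligand from 5-hydroxytryptamine receptor 6 (Homo sapiens) (a lower number here means a stronger inhibitor, a higher number a weaker inhibitor), compound 1 `CN(C)CCn1cc(S(=O)(=O)c2ccccc2)c2cccnc21` gives 23 nM, compound 2 `O=S(=O)(c1cccc(Cl)c1)c1cn(CCN2CCCC2)c2ncccc12` gives 45 nM, and compound 3 `CN(C)CCn1cc(S(=O)(=O)c2cc(Cl)cc(Cl)c2)c2cccnc21` gives 4.3 nM. Among the compounds with values here, compound 3 has the lowest of the three numbers: the one measured step, a 5.3-fold lower number from compound 1 to compound 3 (0.73 log units; beyond the scatter), separates it from compound 1, and the value of compound 2 lies further above it; compound 2 differs from compound 3 in more than one place, so no single step is drawn there. Compound 4 `NCCn1cc(S(=O)(=O)c2cc(Cl)cc(Cl)c2)c2cccnc21` is made from compound 3 by amino in place of dimethylamino on a saturated chain carbon, two bonds along the chain from an aromatic nitrogen. Within the data shown here, no measured step touches this part of the molecule, so the size and direction of this change are untested here. The expected step is a 2.3-fold higher number from compound 3 to compound 4 (0.37 log units; beyond the scatter), a modest move toward a somewhat higher number. Compound 4 is estimated at 10 nM, with a range from 3 nM to 40 nM.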

Compound 4, inhibition constant: 2.9 nM
Compound 4: the middle estimate sits 3.4-fold (0.54 log units) above what was measured; the measured number lies below the stated range.
By their numbers in this assay, from the lowest: compounds 4 and 3 (each within the scatter of the next); then compounds 1 and 2 (each within the scatter of the next).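

With the 3,5-dichlorophenyl group held fixed, the first test at this position, in this assay, gives a 1.5-fold lower number from compound 3 to compound 4 (0.17 log units; within the scatter), so 2-aminoethyl and 2-(dimethylamino)ethyl cannot be told apart here. The two methyl groups on the chain nitrogen are thus not needed for a number in this range in these two compounds. Nothing given here bears on why the two compounds match. As far as these compounds go, whether amino in place of dimethylamino reads the same with the plain phenyl of compound 1 stays open. So does how a methylamino group or a longer chain would read at this position.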